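The source may report more compounds than this note shows. Statements on the series, on what has been measured and on what is new or still open speak of the compounds shown alone.

Compound 2 `O=C(O)c1ccc2noc(-c3ccc(Cc4ccccc4)cc3)c2c1` gives 1290 nM in an assay for inhibition of inositol hexakisphosphate kinase 3 (Homo sapiens), read by colorimetric assay, coupled enzyme assay and malachite green, with a stated time of 120 min, in the presence of a further agent that is not named here (on this read-out lower numbers stand for stronger inhibition and higher numbers for weaker inhibition), and compound 1 `O=C(O)c1ccc2noc(-c3ccc(N4CCCCC4)cc3)c2c1` gives 1790 nM, a number that sits within the scatter of compound 2, since the step of a 1.4-fold lower number from compound 1 to compound 2 (0.14 log units; within the scatter) is small. Compound 3 `O=C(O)c1ccc2noc(-c3ccc(Oc4ccccn4)cc3)c2c1` differs from compound 2 by (pyridin-2-yl)oxy in place of benzyl on an aromatic carbon. Within the data shown here, the only measured step that bears on this position is the one from compound 1 to compound 2, and it stayed within the scatter, so no change beyond the scatter is expected in this assay. Compound 3 is therefore estimated at 1300 nM, with a range from 600 nM to 3000 nM. This expectation amounts to a step of a 1.0-fold higher number from compound 2 to compound 3 (0.00 log units; within the scatter).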

Compound 3, half-maximal inhibitory concentration: 2060 nM
Beside the measured number, compound 3's estimate is 1.6-fold (0.20 log units) below it; measured number inside the range.
By their numbers in this assay, from the lowest: compounds 2, 1 and 3 (each within the scatter of the next).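

In this assay, the change to (pyridin-2-yl)oxy, which has 2 hydrogen-bond acceptors where benzyl has 0, stays within the scatter (a 1.6-fold higher number from compound 2 to compound 3 (0.20 log units; within the scatter)), and so does the comparison with piperidin-1-yl (a 1.2-fold higher number from compound 1 to compound 3 (0.06 log units; within the scatter)). On an aromatic carbon para to a large group, these three groups therefore cannot be told apart by this read-out, now including one joined through oxygen and carrying a ring nitrogen. No available evidence accounts for this.
Still open, going by these compounds, is whether an amine or a longer chain at this position would move the number beyond the scatter.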